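The source may report more compounds than this note shows. Statements on the series, on what has been measured and on what is new or still open speak of the compounds shown alone.

Among the measured compounds shown here, in a functional assay on MGC-803 cells (Homo sapiens) for inhibition, read by MTT assay, with a stated time of 72 h (on this read-out higher numbers stand for weaker inhibition and lower numbers for stronger inhibition), compound 1 (`COc1cccc(NC(=O)C2CCN(C/C=C/c3ccccc3)CC2)c1`) gives 37200 nM, the higher of the two numbers measured so far. Compound 2 (`O=C(Nc1cccc(C(F)(F)F)c1)C1CCN(C/C=C/c2ccccc2)CC1`) gives 9590 nM in this assay. Compound 3 (`O=C(Nc1nccs1)C1CCN(C/C=C/c2ccccc2)CC1`) has not yet been measured. It differs from compound 1 in one place, with 1,3-thiazol-2-yl in place of 3-methoxyphenyl on an amide-type nitrogen.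

For the measured compounds named here, only one measured step bears on this change, and only loosely. It is a 3.9-fold lower number from compound 1 to compound 2 (0.59 log units; beyond the scatter), a modest step beyond the scatter, made by putting trifluoromethyl in place of methoxy on an aromatic carbon. Going by the values given here, that step keeps the aromatic ring, whereas compound 3 replaces the whole 3-methoxyphenyl group, and no measured pair shows such a replacement. In this assay, a small step towards a lower number is therefore expected, probably no larger than the measured one, and the uncertainty in either direction is wide. The expected change is a 1.7-fold lower number from compound 1 to compound 3 (0.23 log units; within the scatter). For compound 3 the estimated value is 22000 nM, with an expected range from 8000 nM to 60000 nM.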

Compound 3, half-maximal inhibitory concentration: 16400 nM
Compound 3: middle estimate off by 1.3-fold (0.13 log units), on the high side; the range from low to high includes it.
By their numbers in this assay, from the lowest: compounds 2 and 3 (each within the scatter of the next); then compound 1.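

In this assay there is a 2.3-fold lower number from compound 1 to compound 3 (0.36 log units; beyond the scatter) and so the whole 3-methoxyphenyl group on the amide-type nitrogen, not only a substituent on it, can be exchanged without the number rising. The entering 1,3-thiazol-2-yl group has fewer heavy atoms and a five-membered aromatic ring with 2 hetero atoms, yet compound 3 stands within the scatter of compound 2, so replacing the ring and changing a substituent on it end at a similar level in this small set. Nothing given here explains why the number falls with this replacement.

The compounds shown leave open whether the change follows the ring size, the ring sulfur or the ring nitrogen, which a 1,3-oxazol-2-yl or a pyridin-2-yl group on the same amide-type nitrogen could begin to separate. They also leave open whether a methyl group, an amine or a carboxylic acid on the 1,3-thiazol-2-yl ring would move the number further in either direction.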